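The source may report more compounds than this note shows. Statements on the series, on what has been measured and on what is new or still open speak of the compounds shown alone.

Measured so far in a functional assay on HCT-116 cells (Homo sapiens) for inhibition, read by sulforhodamine B assay, with a stated time of 48 h, tested at 0.1 uM; on this read-out higher numbers stand for a weaker effect at the one concentration tested and lower numbers for a stronger effect:
- compound 1, `COc1cc(Cl)cc(-c2nn(-c3cccc(NC(=O)Nc4ccc(Cl)c(Cl)c4)c3)cc2-c2ccncc2)c1`: 100%
- compound 2, `COc1cc(Cl)cc(-c2nn(-c3cccc(NC(=O)Nc4cccc(C(F)(F)F)c4)c3)cc2-c2ccncc2)c1`: 99%

Going by the values given here, compound 2 gives the lower of the two numbers, but its only neighbour is compound 1, and the gap between them is within the scatter, so no order between the two can be read from this assay. Among the compounds with values here, the single measured step, a number 1 percentage points lower from compound 1 to compound 2 (within the scatter), swaps one aryl group for another on the amide-type nitrogen and leaves the urea carbonyl and both flanking nitrogens untouched; it shows only that the series sits at the top of the read-out scale at this concentration and does not speak to the next change.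

Compound 3, `COc1cc(Cl)cc(-c2nn(-c3cccc(NC(=O)c4cccc(C(F)(F)F)c4)c3)cc2-c2ccncc2)c1`, differs from compound 2 by 3-(trifluoromethyl)phenyl in place of (3-(trifluoromethyl)phenyl)amino on a carbonyl carbon. Within the data shown here, no measured step covers this kind of change, so the expectation rests on the flat behaviour seen between compound 1 and compound 2 alone. The step is estimated as a number 1 percentage points lower from compound 2 to compound 3 (within the scatter), that is, nothing beyond the scatter. Compound 3 is therefore estimated to give 98% in this assay, with a range from 86% to 106%.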

Compound 3, a percentage reported as activity, at one concentration (the size of the read-out at that concentration, not a potency): 94%
The estimate for compound 3 lay 4 percentage points above the measured number, within the range that was stated.
By their numbers in this assay, from the lowest: compounds 3, 2 and 1 (each within the scatter of the next).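

In this assay, putting 3-(trifluoromethyl)phenyl in place of (3-(trifluoromethyl)phenyl)amino on the carbonyl carbon gives a number 5 percentage points lower from compound 2 to compound 3 (within the scatter) and is the first change shown that touches the link itself rather than only the aryl group: the urea becomes an amide, and the nitrogen with its hydrogen-bond donor leaves. Set against the 3,4-dichlorophenyl urea, the same kind of change gives a number 6 percentage points lower from compound 1 to compound 3 (within the scatter), so at this single concentration neither comparison separates the amide from the ureas, and the flat read-out cannot show whether that nitrogen matters for the effect on these cells. No other measurement on these compounds bears on this result.

Open, from the compounds shown here alone, is whether the amide and the ureas would separate at a concentration where the read-out moves well away from the top of its scale, which would give this comparison something to resolve. Also open, going by these compounds, is how the series responds to other links or groups at this place, such as a sulfonamide in place of the carbonyl, or a morpholine or a carboxylic acid on the terminal phenyl ring.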